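Trifluoro step at the limit of the assay

A few compounds are considered here, and "the series" means these few. Any claim that something is new, unique, unknown or untested is made for them only; others in the source may bear on it.

Measured in a functional assay on NALM-6 cells (Homo sapiens) for cytotoxicity, with a stated time of 72 h (on this read-out lower numbers stand for an effect already at smaller amounts and higher numbers for an effect only at larger amounts of compound), as follows:
Compound 1 `C=C[C@@](C)(/C=C/c1ccc(Nc2ccc(OC)c(F)c2)cc1)CCC=C(C)C` gives > 43400 nM as a limit
Compound 2 `C=C[C@@](C)(/C=C/c1ccc(Nc2ccc(F)cc2)cc1)CCC=C(C)C` gives > 43400 nM as a limit
Compound 3 `C=C[C@@](C)(/C=C/c1ccc(Nc2cc(F)cc(F)c2)cc1)CCC=C(C)C` gives > 43400 nM as a limit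

Compound 3 has only a limit, > 43400 nM and no number. Going by the values given here, the series so far shows the limit of > 43400 nM in this assay, at which 3 of the 3 values shown sit, and no measured value. Compound 4 `C=C[C@@](C)(/C=C/c1ccc(Nc2cc(F)c(F)c(F)c2)cc1)CCC=C(C)C` differs from compound 3 by fluoro in place of hydrogen on an aromatic carbon as fluoro in place of hydrogen on an aromatic carbon, 3,5-difluorophenyl to 3,4,5-trifluorophenyl. Bearing on it are a step that the two limits leave unreadable from compound 2 to compound 3 and a step that the two limits leave unreadable from compound 1 to compound 3 together with a step that the two limits leave unreadable from compound 1 to compound 2 and none gives a size. In this assay no step beyond the scatter is expected, and another limit is the likely report. The estimate means a step that the limit leaves unreadable from compound 3 to compound 4 as the expected outcome. For compound 4 the estimated value is 50000 nM with an expected range from 25000 nM to 90000 nM for now.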

Compound 4, half-maximal effective concentration: > 43400 nM
Compound 4 ended at the assay's limit; the forecaster's own chance of this, stated with the estimate: 85%; the middle value does not contradict the limit.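

Compound 4 gives > 43400 nM, a limit, and its steps from compound 1, compound 2 and compound 3 cannot be read. What stays open is whether any of the four compounds reaches a measurable value: the limit of > 43400 nM in this assay, at which 4 of the 4 values shown sit.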